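Methoxy on the phenyl of compound 3: expected MAPKAPK2 inhibition

This account rests on a few compounds, and the source may have more. Where it says the series, first, only, none or still open, it means among the compounds named here.

Measured compounds:
compound 1 `Cc1cc2c(c(NS(C)(=O)=O)nn2C)c(=O)[nH]1`: 1%
compound 2 `COc1ccc(S(=O)(=O)Nc2nn(C)c3cc(C)[nH]c(=O)c23)c(OC)c1`: 2%
compound 3 `Nc1c2c(=O)[nH]c(-c3ccccc3)cc2nn1-c1ccccc1`: 2%

In an assay on isolated protein for inhibition of MAP kinase-activated protein kinase 2 (Homo sapiens), read by mobility shift assay, tested at 30 uM (on this read-out lower numbers stand for less inhibition and higher numbers for more inhibition at the one concentration tested (going by the name of the read-out)), compound 3 gives 2%, level with compound 2 at the digits shown and within the scatter of compound 1, so the three sit together near the bottom of the read-out. Compound 4 `COc1ccccc1-c1cc2nn(-c3ccccc3)c(N)c2c(=O)[nH]1` differs from compound 3 by methoxy in place of hydrogen on an aromatic carbon, placed on an aromatic carbon of a six-membered aromatic ring of carbon only; cut one bond further out, the change reads phenyl to 2-methoxyphenyl. Within the data shown here, no measured pair shows what this methoxy does here. With all three values of this assay lying low and close, the step of a number 1 percentage points higher from compound 3 to compound 4 (within the scatter) is expected to stay within the scatter, in no clear direction. Compound 4 is therefore expected to give 3%, with a range from 0% to 15%.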

Compound 4, a percentage reported as inhibition, at one concentration (the size of the read-out at that concentration, not a potency): -1%
Compound 4: the middle estimate sits 4 percentage points above what was measured; the whole stated range lies above it.
By their numbers in this assay, from the lowest: compounds 4, 1, 2 and 3 (each within the scatter of the next).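

In this assay, the change from phenyl to 2-methoxyphenyl gives a number 3 percentage points lower from compound 3 to compound 4 (within the scatter). Among these compounds, this is the first measured pair at this position, and methoxy on this aromatic carbon, ortho to a large group, brings no inhibition that stands clear of the scatter. No measurement at hand bears on the reason for this reading.

On these data alone, whether an amine or a carboxylic acid on the same carbon would give a reading beyond the scatter stays open. So does the effect of methoxy on another carbon of this ring.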